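Benzyl triazole ethers on a shared core: nitro analogue

The compounds below may be only part of what the source reports. "The series", "measured", "known", "first", "only" and "open" are said of these compounds alone.

Measured in a functional assay on HeLa cells (Homo sapiens) for cytotoxicity, read by MTT assay, with a stated time of 48 h; a lower number here means a stronger inhibitor, a higher number a weaker inhibitor:
- compound 1, `O=c1ccoc2cc(OCc3cn(Cc4ccccc4)nn3)ccc12`, a limit only: > 100000 nM
- compound 2, `O=c1ccoc2cc(OCc3cn(Cc4cccc(Br)c4)nn3)ccc12`, a limit only: > 100000 nM
- compound 3, `O=c1ccoc2cc(OCc3cn(Cc4cccc(Cl)c4)nn3)ccc12`, a limit only: > 100000 nM

Compound 1 stands at the limit of this assay, not at a number. The steps from compound 1 to compound 2 and from compound 1 to compound 3 cannot be read: a step that the two limits leave unreadable from compound 1 to compound 2 and a step that the two limits leave unreadable from compound 1 to compound 3. The same holds for a step that the two limits leave unreadable from compound 2 to compound 3. Among the measured compounds shown here, the only evidence on the series is the limit of > 100000 nM in this assay, at which 3 of the 3 values shown sit.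

Compound 4, `O=c1ccoc2cc(OCc3cn(Cc4cccc([N+](=O)[O-])c4)nn3)ccc12`, differs from compound 1 by nitro in place of hydrogen on an aromatic carbon. For the measured compounds named here, no measured step bears on it in size, since bromo and chloro at the same place each left the value at the limit. In this assay compound 4 is therefore expected to stay at the limit as well, with an expected step of a number no higher from compound 1 to compound 4 (the limit leaves the size open). The estimate for compound 4 is 100000 nM, within 30000 nM to 300000 nM.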

Compound 4, half-maximal inhibitory concentration: 17300 nM
For compound 4 the middle estimate is 5.8-fold (0.76 log units) above the measured one; measured number outside the range, below it.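

In this assay this place on the phenyl ring can respond to substitution: nitro in place of hydrogen gives an at least 5.7-fold lower number from compound 1 to compound 4 (0.76 log units; beyond the scatter). The identity of the group matters, since nitro in place of chloro gives an at least 5.7-fold lower number from compound 3 to compound 4 (0.76 log units; beyond the scatter) and nitro in place of bromo gives an at least 5.7-fold lower number from compound 2 to compound 4 (0.76 log units; beyond the scatter). All three steps are lower bounds, and the steps among compound 1, compound 2 and compound 3 cannot be read: the limit of > 100000 nM in this assay, at which 3 of the 4 values shown sit.

From the compounds shown here alone, whether the drop in value is peculiar to nitro or extends to other groups at this place, such as an amine or a carboxylic acid, stays open. Also open, going by these compounds, is whether nitro elsewhere on the phenyl ring, or a change on the shared core, would shift the value in this assay.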